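Removing the methoxy group: from compound 1 to compound 4

This account rests on a few compounds, and the source may have more. Where it says the series, first, only, none or still open, it means among the compounds named here.

Measured so far in an assay on mitochondria from L6 cells (Rattus norvegicus) for activation, with a stated time of 90 min; a lower number here means that less compound is needed, a higher number that more compound is needed for the effect:
- compound 1 `COc1cccc(Nc2nc3nonc3nc2O)c1`; compound 1 gives 75400 nM
- compound 2 `Cc1cc(Nc2nc3nonc3nc2O)ccc1OCC(F)(F)F`; compound 2 gives 7000 nM
- compound 3 `Oc1nc2nonc2nc1Nc1ccc(OCC(F)(F)F)c(F)c1`; compound 3 gives 10400 nM

Compound 1 stands at the highest number of the three in this assay; compound 3 is nearest to it and compound 2 furthest, both beyond the scatter, so compound 1 needs clearly more compound than either.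

Compound 4 `Oc1nc2nonc2nc1Nc1ccccc1` differs from compound 1 in one place: hydrogen in place of methoxy on an aromatic carbon

Among the measured compounds shown here, only one step between measured compounds that differ in one place is known, a 1.5-fold higher number from compound 2 to compound 3 (0.17 log units; within the scatter), and it concerns a different group on a differently substituted ring. For the measured compounds named here, no measured pair shows a methoxy group being removed, so no step bears directly on this change, and its direction cannot be read from the data. In this assay compound 4 is therefore expected to stay close to compound 1, with a wide range to either side: the estimate is 60000 nM, between 20000 nM and 200000 nM. The expected step is a 1.3-fold lower number from compound 1 to compound 4 (0.10 log units; within the scatter).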

Compound 4, half-maximal effective concentration: 66700 nM
Compound 4: middle estimate off by 1.1-fold (0.05 log units), on the low side, within the range that was stated.
By their numbers in this assay, from the lowest: compounds 2 and 3 (each within the scatter of the next); then compounds 4 and 1 (each within the scatter of the next).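

Hydrogen in place of methoxy on an aromatic carbon, meta to a large group, is the first change at this position, and in this assay it gives a 1.1-fold lower number from compound 1 to compound 4 (0.05 log units; within the scatter) and stays within the scatter. The methoxy group is therefore not required at this position for the number seen with compound 1, at least on an otherwise unsubstituted ring. No available measurement explains why the two compounds lie so close together.

Still open, on these data alone, is whether an amine, a carboxylic acid or a longer chain such as butoxy at this position would give a step beyond the scatter. As far as these compounds go, it is also open whether removing a methoxy group would give a similar step on a ring that carries further substituents.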